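The source may report more compounds than this note shows. Statements on the series, on what has been measured and on what is new or still open speak of the compounds shown alone.

Measured compounds:
- compound 1 `C[C@H]1CC[C@@H]2[C@@H](OC(=O)[C@]23CC(c2ccccc2Br)=NO3)[C@]2(C)C(=O)C=C[C@@]12O`: 18000 nM
- compound 2 `C[C@H]1CC[C@@H]2[C@@H](OC(=O)[C@]23CC(c2ccc(N(C)C)cc2)=NO3)[C@]2(C)C(=O)C=C[C@@]12O`: 4500 nM
- compound 3 `Cc1cccc(C2=NO[C@]3(C2)C(=O)O[C@@H]2[C@H]3CC[C@H](C)[C@]3(O)C=CC(=O)[C@@]23C)c1`: 28000 nM

All three were tested in a functional assay on DU-145 cells (Homo sapiens) for cytotoxicity, read by sulforhodamine B assay, with a stated time of 48 h; on this read-out lower numbers stand for stronger inhibition and higher numbers for weaker inhibition. Compound 2 gives the lowest number of the three: a 4.0-fold lower number from compound 1 to compound 2 (0.60 log units; beyond the scatter) and a 6.2-fold higher number from compound 2 to compound 3 (0.79 log units; beyond the scatter) are both beyond the scatter, while compound 1 and compound 3 lie within the scatter of each other (a 1.6-fold higher number from compound 1 to compound 3 (0.19 log units; within the scatter)).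

Compound 4 `C[C@H]1CC[C@@H]2[C@@H](OC(=O)[C@]23CC(c2ccc(F)cc2)=NO3)[C@]2(C)C(=O)C=C[C@@]12O` differs from compound 2 by fluoro in place of dimethylamino on an aromatic carbon. Both steps that touch compound 2 point the same way: removing the dimethylamino group in favour of another aryl substituent raised the number, once by a 4.0-fold lower number from compound 1 to compound 2 (0.60 log units; beyond the scatter) read in reverse and once by a 6.2-fold higher number from compound 2 to compound 3 (0.79 log units; beyond the scatter). A step upward, beyond the scatter, is therefore expected for compound 4, a 3.3-fold higher number from compound 2 to compound 4 (0.52 log units; beyond the scatter), placing it near compound 1 and compound 3. The estimate for compound 4 is 15000 nM, range 6000 nM to 40000 nM.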

Compound 4, half-maximal inhibitory concentration: 13000 nM
Beside the measured number, compound 4's estimate is 1.2-fold (0.06 log units) above it, and the stated range covers the measured number.
By their numbers in this assay, from the lowest: compound 2; then compounds 4, 1 and 3 (each within the scatter of the next, the first and the last beyond it).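

Fluoro in place of dimethylamino on the same aromatic carbon, para to a large group, gives a 2.9-fold higher number from compound 2 to compound 4 (0.46 log units; beyond the scatter), so the step holds with the position unchanged and only the substituent swapped. The 4-fluorophenyl group stays within the scatter of 2-bromophenyl, a 1.4-fold lower number from compound 1 to compound 4 (0.14 log units; within the scatter), but separates from 3-methylphenyl, a 2.2-fold lower number from compound 3 to compound 4 (0.33 log units; beyond the scatter). No evidence on hand bears on why dimethylamino stands apart.

As far as these compounds go, whether the lower number needs dimethylamino itself stays open. A primary amine or a methoxy group on that aromatic carbon would bear on this.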